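Amide aryl variation on the shared core: compound 4

The source may hold more compounds than are shown below. What is called first, only, known or untested is meant among the compounds shown, and "the series" means these compounds.

For the measured compounds named here, measured so far: compound 1 `O=C(Nc1ccc(Cl)c(-c2nnc3c(Cl)cccn23)c1)c1ccc(F)cc1Cl` and compound 2 `Cc1cc(Cl)ccc1C(=O)Nc1ccc(Cl)c(-c2nnc3c(Cl)cccn23)c1` are limits in a functional assay on AN3-CA cells (Homo sapiens) for antiproliferative activity, read by MTT assay, with a stated time of 72 h; a lower number here means a stronger inhibitor, a higher number a weaker inhibitor; compound 3 `O=C(Nc1ccc(Cl)c(-c2nnc3c(Cl)cccn23)c1)c1ccc(Cl)cc1Cl` is the single number.

In this assay compound 1 gives > 100000 nM, a limit of the assay. Compound 2 likewise gives > 100000 nM, also a limit. Compound 3 gives 84800 nM, the only number shown, the other two values sitting at the limit of > 100000 nM in this assay, at which 2 of the 3 values shown sit. The steps of an at least 1.1-fold lower number from compound 1 to compound 3 (0.07 log units; that floor lies within the scatter) and an at least 1.1-fold lower number from compound 2 to compound 3 (0.07 log units; that floor lies within the scatter) are floors only, so the size of either is not readable.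

Compound 4 `CS(=O)(=O)c1cccc(C(=O)Nc2ccc(Cl)c(-c3nnc4c(Cl)cccn34)c2)c1` carries 3-(methylsulfonyl)phenyl in place of 2,4-dichlorophenyl on a carbonyl carbon. The two measured steps bear on it only in showing that other aryl amides reach no number, so no direction beyond the scatter is expected. The estimated step is a 1.1-fold higher number from compound 3 to compound 4 (0.03 log units; within the scatter). Compound 4 is expected at 90000 nM, within 25000 nM to 300000 nM.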

Compound 4, half-maximal inhibitory concentration: > 100000 nM
Compound 4 gave a limit, no number; the forecaster's own chance of this, stated with the estimate: 50%; at least 1.1-fold (0.04 log units) between middle value and limit.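

Compound 4 stands at a limit, not a number, so 3-(methylsulfonyl)phenyl in place of 2,4-dichlorophenyl on the carbonyl carbon gives only a floor, an at least 1.1-fold higher number from compound 3 to compound 4 (0.07 log units; that floor lies within the scatter). The steps from compound 1 and compound 2 to compound 4 join two limits and cannot be read. An aryl group with hydrogen-bond acceptors thus also reaches no number at this position, with compound 3 the sole exception: the limit of > 100000 nM in this assay, at which 3 of the 4 values shown sit.

Still open, from the compounds shown here alone, is whether an amine or a carboxylic acid on this aryl ring, or a longer alkyl chain in its place, would give a readable number in this assay. Going by these compounds, how far these amides truly differ beyond the limit also remains unknown.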